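Methyl to ethyl on the aryl sulfide of compound 1

This account rests on a few compounds, and the source may have more. Where it says the series, first, only, none or still open, it means among the compounds named here.

Compound 1 `Cc1ccc(SCc2ccc(/C=C/C(=O)Nc3ccccc3N)cc2)cc1` is examined in a functional assay on A-375 cells (Homo sapiens) for inhibition, read by CCK-8 assay, with a stated time of 72 h, tested at 8 uM (on this read-out lower numbers stand for less inhibition of growth and higher numbers for more inhibition of growth at the one concentration tested), where compound 1 gives 31.2%. This is the lowest of the three measured numbers. Compound 2 `Nc1ccccc1NC(=O)c1ccc(CSc2ccc(Cl)cc2)cc1` gives 48.6% in this assay, and compound 3 `Nc1ccccc1NC(=O)c1ccc(CSCCc2ccccc2)cc1` gives 69.9%. Among the measured compounds shown here, the only single-point step among the measured compounds, a number 21.3 percentage points higher from compound 2 to compound 3 (beyond the scatter), concerns the group on the sulfur and not the small change considered here.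

Compound 4 `CCc1ccc(SCc2ccc(/C=C/C(=O)Nc3ccccc3N)cc2)cc1` differs from compound 1 by methyl in place of hydrogen on a saturated chain carbon bound to an aromatic carbon. For the measured compounds named here, no measured step touches this position, so nothing in the data speaks for a shift in either direction. Compound 4 is therefore expected to stay close to compound 1, with a step of a number 1.8 percentage points higher from compound 1 to compound 4 (within the scatter) in this assay, not beyond the scatter. The estimate for compound 4 in this assay is 33%, with a range from 20% to 48%.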

Compound 4, percent growth inhibition at one concentration: 58.4%
Compound 4: the middle estimate sits 25.4 percentage points below what was measured; measured number outside the range, above it.
By their numbers in this assay, from the lowest: compound 1; then compounds 2 and 4 (each within the scatter of the next); then compound 3.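

The change from 4-methylphenyl to 4-ethylphenyl on the sulfur is not a silent one in this assay: a single added methyl, on a saturated chain carbon bound to an aromatic carbon, gives a number 27.2 percentage points higher from compound 1 to compound 4 (beyond the scatter). Among the compounds shown here, the only earlier step in one place, a number 21.3 percentage points higher from compound 2 to compound 3 (beyond the scatter), replaced the whole group on the sulfur, whereas this result shows that the read-out also responds to a small extension of that group on the core of compound 1. Nothing in the available data accounts for the size of this step.

As far as these compounds go, whether the number keeps rising with a longer chain such as propyl, or holds with a methoxy group or an amine in the same place, remains open. Also open, from the compounds shown here alone, is whether the same methyl-to-ethyl change would give a comparable step on the core of compound 2.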